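A Benzyl Chain on the Shared Core of Compound 3

This account rests on a few compounds, and the source may have more. Where it says the series, first, only, none or still open, it means among the compounds named here.

Compound 3 `CCCCn1cc(C(=O)OCC)c(=O)c2ccc(Cl)cc21` carries a butyl chain on the aromatic nitrogen of the shared core. In a functional assay on HeLa cells (Homo sapiens) for cytotoxicity, read by MTT assay, with a stated time of 24 h (on this read-out higher numbers stand for weaker inhibition and lower numbers for stronger inhibition), compound 3 reaches only the limit > 50000 nM. Compound 2 `C=CCn1cc(C(=O)OCC)c(=O)c2ccc(Cl)cc21` likewise reaches only the limit > 50000 nM. Compound 1 `CCOC(=O)c1cn(CCCc2ccccc2)c2cc(Cl)ccc2c1=O`, with a phenylpropyl chain in the same place, gives 14800 nM. Compound 4 `CCOC(=O)c1cn(Cc2ccccc2)c2cc(Cl)ccc2c1=O` differs from compound 3 by phenyl in place of propyl on a saturated chain carbon bound to an aromatic nitrogen. The step of an at least 3.3-fold higher number from compound 1 to compound 3 (0.52 log units; beyond the scatter) shows that trading the phenyl for methyl weakened inhibition, whereas a step that the two limits leave unreadable from compound 2 to compound 3 and an at least 3.3-fold higher number from compound 1 to compound 2 (0.52 log units; beyond the scatter) cannot be read because compound 2 and compound 3 sit at the limit of > 50000 nM in this assay, at which 2 of the 3 values shown sit. Given an at least 3.3-fold higher number from compound 1 to compound 3 (0.52 log units; beyond the scatter), compound 4 is expected to show a lower number in this assay, by an at least 2.5-fold lower number from compound 3 to compound 4 (0.39 log units; beyond the scatter). Compound 4 is estimated at 20000 nM, within 7000 nM to 60000 nM.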

Compound 4, half-maximal inhibitory concentration: 16200 nM
Compound 4: middle estimate off by 1.2-fold (0.09 log units), on the high side, within the range that was stated.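

In this assay, the step of an at least 3.0-fold lower number from compound 3 to compound 4 (0.48 log units; beyond the scatter) and the step of an at least 3.0-fold lower number from compound 2 to compound 4 (0.48 log units; beyond the scatter) show that a phenyl on the saturated chain carbon bound to an aromatic nitrogen is enough to give a readable value, without the longer chain of compound 1. The phenylpropyl and benzyl chains stand level, with a 1.1-fold higher number from compound 1 to compound 4 (0.04 log units; within the scatter), so across these two chains the length does not separate the compounds.

How large the first two steps really are stays open: the limit of > 50000 nM in this assay, at which 2 of the 4 values shown sit.

As far as these compounds go, whether an amine or a carboxylic acid on the phenyl would keep this inhibition also stays open.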